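The source may report more compounds than this note shows. Statements on the series, on what has been measured and on what is new or still open speak of the compounds shown alone.

Measured in a functional assay on BXPC-3 cells (Homo sapiens) for antiproliferative activity, read by MTT assay, with a stated time of 24 h; a lower number here means a stronger inhibitor, a higher number a weaker inhibitor:
- compound 1 `CCn1c(C(=O)N[C@@H](C)C(=O)OC)ccc1C(CC)(CC)c1ccc(OCS(=O)(=O)c2ccccc2)c(C)c1`: 17900 nM
- compound 2 `CCn1c(C(=O)N[C@@H](CC(=O)OC)C(=O)OC)ccc1C(CC)(CC)c1ccc(OCS(=O)(=O)c2ccccc2)c(C)c1`: > 50000 nM (a limit of the assay, not a number)
- compound 3 `CCn1c(C(=O)NCCO)ccc1C(CC)(CC)c1ccc(OCS(=O)(=O)c2ccccc2)c(C)c1`: 19900 nM

Among the measured compounds shown here, compound 2 is known only through its limit of > 50000 nM, and it is the one compound that sits there: the limit of > 50000 nM in this assay, at which 1 of the 3 values shown sits.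

The next compound to read is compound 4 `CCn1c(C(=O)NC(C)(C)CO)ccc1C(CC)(CC)c1ccc(OCS(=O)(=O)c2ccccc2)c(C)c1`, where 1-(hydroxymethyl)-1-methylethyl takes the place of 1,2-bis(methoxycarbonyl)ethyl on an amide-type nitrogen (1-(hydroxymethyl)-1-methylethyl in place of 1,2-bis(methoxycarbonyl)ethyl on an amide-type nitrogen).

The closest measured step is an at least 2.5-fold lower number from compound 2 to compound 3 (0.40 log units; beyond the scatter), which removes the same group in favour of 2-hydroxyethyl. an at least 2.7-fold higher number from compound 1 to compound 2 (0.44 log units; beyond the scatter) also bears on it, since that step adds methoxycarbonyl on a saturated chain carbon. The third step, a 1.1-fold higher number from compound 1 to compound 3 (0.05 log units; within the scatter), lies within the scatter, so the two compounds that lack the second ester give one level in this assay. For the measured compounds named here, no measured compound carries 1-(hydroxymethyl)-1-methylethyl, so that level is borrowed and the range stays wide.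

On the evidence of compound 3 at 19900 nM, the expected change is of similar size and towards a lower number, giving an expected at least 2.5-fold lower number from compound 2 to compound 4 (0.39 log units; beyond the scatter).

The estimate for compound 4 is 20000 nM, with an expected range of 8000 nM to 45000 nM.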

Compound 4, half-maximal inhibitory concentration: 18300 nM
Estimate against measurement, compound 4: 1.1-fold (0.04 log units) above; low and high end bracket the measured number.
By their numbers in this assay, from the lowest: compounds 1, 4 and 3 (each within the scatter of the next). At a limit, above all of these: compound 2.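

In this assay, 1-(hydroxymethyl)-1-methylethyl on the amide-type nitrogen gives a 1.1-fold lower number from compound 3 to compound 4 (0.04 log units; within the scatter) in place of 2-hydroxyethyl and a 1.0-fold higher number from compound 1 to compound 4 (0.01 log units; within the scatter) in place of 1-(methoxycarbonyl)ethyl, so three different groups at this position now read as a single level, and a hydroxyl-bearing group with two extra methyl carbons does not move the result away from it. Against 1,2-bis(methoxycarbonyl)ethyl the change gives an at least 2.7-fold lower number from compound 2 to compound 4 (0.43 log units; beyond the scatter), which makes compound 2, the only compound shown with that group, the sole departure from this level, and the size of that departure is only a bound. Compound 2 is held at a limit of the assay, not a number: the limit of > 50000 nM in this assay, at which 1 of the 4 values shown sits.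

The compounds shown leave open whether anything on this nitrogen can bring the number below the shared level, since each group tried so far either stays on it or lies at the limit. A primary amine, a free carboxylic acid or a longer hydroxyalkyl chain at this position would test whether that level holds beyond these groups.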